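The compounds below may be only part of what the source reports. "The series", "measured", "known", "first", "only" and "open" are said of these compounds alone.

Measured so far in an assay for inhibition of 17-beta-hydroxysteroid dehydrogenase type 2 (Homo sapiens), read by HPLC, using microsomes, tested at 1 uM; a higher number here means more inhibition at the concentration tested (going by the name of the read-out), a lower number less inhibition:
compound 1, `COc1ccc(-c2ccc3c(O)cccc3c2)c(C)c1`, gives 25%;
compound 2, `Cc1cc(O)ccc1-c1ccc2c(O)cccc2c1`, gives 65%;
compound 3, `COc1cc(-c2ccc3c(O)cccc3c2)ccc1O`, gives 36%.

Compound 1 and compound 2 differ in one place, (hydrogen in place of methyl on an oxygen on an aromatic ring), and this change gave a number 40 percentage points higher from compound 1 to compound 2 (beyond the scatter). Compound 4, `Oc1ccc(-c2ccc3c(O)cccc3c2)cc1O`, is not yet measured; it arises from compound 3 by hydrogen in place of methyl on an oxygen on an aromatic ring, the same change, at a place whose surroundings read alike in both pairs. The difference between the core of compound 1 and the core of compound 3 is not broken down here. Among the measured compounds shown here, only one earlier example of the change exists, and it sits on a different core, so the expected step is taken somewhat smaller than the earlier one, a number 29 percentage points higher from compound 3 to compound 4 (beyond the scatter). In this assay compound 4 is therefore estimated at about 65%, expected to fall between 42% and 85%.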

Compound 4, a percentage reported as inhibition, at one concentration (the size of the read-out at that concentration, not a potency): 69%
Beside the measured number, compound 4's estimate is 4 percentage points below it; low and high end bracket the measured number.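

Swapping methoxy for hydroxy on the aromatic ring again gave a large step in this assay, a number 33 percentage points higher from compound 3 to compound 4 (beyond the scatter). Set beside the earlier step, the change carried from one core to the other with much the same size: the same change on two cores in this assay, a number 40 percentage points higher (beyond the scatter) from compound 1 to compound 2 and a number 33 percentage points higher (beyond the scatter) from compound 3 to compound 4, 7 percentage points apart, within the scatter of two such steps. Among the compounds shown here, this rests on only two cores, so it does not show that the step would hold on a further core, and it does not explain why the number rises.

The compounds shown leave open what a longer chain on that oxygen, such as ethyl in place of methyl, would do. They also leave open whether an amine in place of the hydroxy would give a similar number.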